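This account rests on a few compounds, and the source may have more. Where it says the series, first, only, none or still open, it means among the compounds named here.

Measured in an ADME assay on A549 cells (Homo sapiens) for cytotoxicity, read by MTT assay, with a stated time of 72 h; on this read-out higher numbers stand for weaker inhibition and lower numbers for stronger inhibition:

- compound 1 `c1ccc(-c2nnc(-c3ccc(-n4cccc4)cc3)o2)cc1` — 256000 nM
- compound 2 `Brc1ccc(-c2nnc(-c3ccc(-n4cccc4)cc3)o2)cc1` — 264000 nM
- compound 3 `O=[N+]([O-])c1ccc(-c2nnc(-c3ccc(-n4cccc4)cc3)o2)cc1` — 258000 nM

The three numbers for the shared core carrying hydrogen, bromo or nitro on the outer ring lie on top of one another. Compound 3 sits among them with no separation from either neighbour: a 1.0-fold higher number from compound 1 to compound 3 (0.00 log units; within the scatter) and a 1.0-fold lower number from compound 2 to compound 3 (0.01 log units; within the scatter), both within the scatter, as is a 1.0-fold higher number from compound 1 to compound 2 (0.01 log units; within the scatter). Nothing in this set moves the cytotoxicity read-out.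

Compound 4 `Clc1ccc(-c2nnc(-c3ccc(-n4cccc4)cc3)o2)cc1` differs from compound 3 by chloro in place of nitro on an aromatic carbon. The step that bears most directly on it is the exchange of one substituent for another at the same place, a 1.0-fold lower number from compound 2 to compound 3 (0.01 log units; within the scatter), which was flat; the halogen-for-hydrogen step, a 1.0-fold higher number from compound 1 to compound 2 (0.01 log units; within the scatter), was equally flat. A halogen replacing a nitro group at this position is therefore expected to give a step of no more than the scatter in this assay, with no direction to call: no change at the digits printed from compound 3 to compound 4 (within the scatter) is the expected step.

For compound 4 the estimate in this assay is 258000 nM, with a range from 180000 nM to 370000 nM; the measured value is awaited.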

Compound 4, half-maximal inhibitory concentration: 256000 nM
For compound 4 the middle estimate is 1.0-fold (0.00 log units) above the measured one; the measured number falls inside the stated range.
By their numbers in this assay, from the lowest: compounds 1, 4, 3 and 2 (each within the scatter of the next).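

In this assay, chloro on this aromatic carbon, para to a large group, joins the flat set: no change at the digits printed from compound 1 to compound 4 (within the scatter), a 1.0-fold lower number from compound 2 to compound 4 (0.01 log units; within the scatter) and a 1.0-fold lower number from compound 3 to compound 4 (0.00 log units; within the scatter). With a second halogen now in the series, the read-out separates chloro neither from bromo nor from hydrogen or nitro, so the exchange of nitro for a single chlorine atom at this position leaves no trace beyond the scatter, and the flatness now spans four substituents rather than three. No supporting measurement is available here to say why the read-out stays level across these substituents.

Still open, on these data alone, is whether an amine, a carboxylic acid or a longer chain at this position would depart from the level of compound 1, 256000 nM, in this assay. All four compounds differ at this one place only; whether the read-out is equally level for a change elsewhere on the shared core remains an open question.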